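Lengthening the Amine Side Chain of Compound 3

The compounds below may be only part of what the source reports. "The series", "measured", "known", "first", "only" and "open" are said of these compounds alone.

Measured in a functional assay on SK-HEP1 cells (Homo sapiens) for antiproliferative activity, read by sulforhodamine B assay, with a stated time of 72 h; on this read-out lower numbers stand for stronger inhibition and higher numbers for weaker inhibition:
- Compound 1 `COc1ncc(-c2ccc3ncnc(NCCN(C)C)c3c2)cc1NS(C)(=O)=O`: 12600 nM
- Compound 2 `COc1ncc(-c2ccc3ncnc(NCc4ccncc4)c3c2)cc1NS(=O)(=O)c1ccc(F)cc1F`: 12400 nM
- Compound 3 `COc1ncc(-c2ccc3ncnc(NCCN(C)C)c3c2)cc1NS(=O)(=O)c1ccc(F)cc1F`: 4720 nM

Compound 3 has the lowest number of these three, and both others lie beyond the scatter from it. Compound 4 `COc1ncc(-c2ccc3ncnc(NCCCN(C)C)c3c2)cc1NS(=O)(=O)c1ccc(F)cc1F` differs from compound 3 by (dimethylamino)methyl in place of dimethylamino on a saturated chain carbon, two bonds along the chain from a nitrogen on an aromatic ring. It carries (dimethylamino)methyl in place of dimethylamino on a saturated chain carbon, two bonds along the chain from a nitrogen on an aromatic ring.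

Going by the values given here, no measured step makes this exact change. The closest is a 2.6-fold lower number from compound 2 to compound 3 (0.42 log units; beyond the scatter), which alters the same chain. The other, a 2.7-fold lower number from compound 1 to compound 3 (0.43 log units; beyond the scatter), changes the group on the sulfonyl sulfur and shows only how large steps in this small set have been. Among the compounds with values here, both are modest, and the new change is smaller than the one in the closest step.

The expected result is a 1.0-fold lower number from compound 3 to compound 4 (0.02 log units; within the scatter), so no step beyond the scatter is expected in this assay. Here compound 4 is estimated at 4500 nM, with an expected range from 2000 nM to 10000 nM.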

Compound 4, half-maximal inhibitory concentration: 4680 nM
Estimate against measurement, compound 4: 1.0-fold (0.02 log units) below; low and high end bracket the measured number.
By their numbers in this assay, from the lowest: compounds 4 and 3 (each within the scatter of the next); then compounds 2 and 1 (each within the scatter of the next).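

Moving from the (2-(dimethylamino)ethyl)amino side chain to the (3-(dimethylamino)propyl)amino side chain in this assay gives a 1.0-fold lower number from compound 3 to compound 4 (0.00 log units; within the scatter), so this position accepts one more chain carbon with no measurable change in this read-out. The longer chain also keeps the advantage over the pyridin-4-yl group of compound 2, with a 2.6-fold lower number from compound 2 to compound 4 (0.42 log units; beyond the scatter), a modest step of the same size as a 2.6-fold lower number from compound 2 to compound 3 (0.42 log units; beyond the scatter). Nothing available explains why the two chain lengths read alike.

On these data alone, whether a still longer chain, such as 4-(dimethylamino)butyl, would also read the same remains open. So does whether the chain needs its dimethylamino end at all, a question that a chain ending in a hydroxyl group or in a morpholine ring could address.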